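The source may hold more compounds than are shown below. What is called first, only, known or untested is meant among the compounds shown, and "the series" means these compounds.

Working notes on the series, read in an ADME assay on Vero cells (Chlorocebus sabaeus) for cytotoxicity, read by MTT assay; on this read-out lower numbers stand for higher toxicity in this test and higher numbers for lower toxicity in this test. Compound 2 `COc1ccc(-c2nc3cnccn3c2Nc2cc(OC)c(OC)c(OC)c2)cc1` gives 75000 nM, and compound 1 `COc1ccc(-c2nc3ccccn3c2Nc2cc(OC)c(OC)c(OC)c2)cc1O` gives 50000 nM, within the scatter of it. Compound 3 `COc1cc(Nc2c(-c3ccc(Cl)cc3)nc3cnccn23)cc(OC)c1OC` gives 32000 nM. Compound 2 thus sits with compound 1 at the upper end of the three numbers, and only compound 3 stands clearly apart.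

The next compound to read is compound 4 `COc1cc(-c2nc3cnccn3c2Nc2cc(OC)c(OC)c(OC)c2)cc(OC)c1O`. The change is 4-hydroxy-3,5-dimethoxyphenyl in place of 4-methoxyphenyl on an aromatic carbon, with 4-hydroxy-3,5-dimethoxyphenyl in place of 4-methoxyphenyl on an aromatic carbon, while the shared core stays the same.

Within the data shown here, only one measured step alters this same group: chloro in place of methoxy gave a 2.3-fold lower number from compound 2 to compound 3 (0.37 log units; beyond the scatter), a modest step. Compound 1 also carries a hydroxy group on its aryl ring and stands at 50000 nM, but it differs from compound 2 in the core as well, so it offers only loose guidance. Among the measured compounds shown here, no measured compound tests this exact group on the shared core.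

A small move towards lower numbers is therefore expected, no larger than the modest step already seen, and it is estimated as a 1.5-fold lower number from compound 2 to compound 4 (0.18 log units; within the scatter). For compound 4 the expected value is 50000 nM, with an estimated range of 20000 nM to 110000 nM.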

Compound 4, concentration lethal to 50% of the cells: 62000 nM
For compound 4 the middle estimate is 1.2-fold (0.09 log units) below the measured one; low and high end bracket the measured number.
By their numbers in this assay, from the lowest: compounds 3, 1, 4 and 2 (each within the scatter of the next, the first and the last beyond it).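

In this assay the 4-hydroxy-3,5-dimethoxyphenyl group on this aromatic carbon of the shared core gives a 1.2-fold lower number from compound 2 to compound 4 (0.08 log units; within the scatter) and so stays within the scatter of the 4-methoxyphenyl group, which shows that this position accepts the larger group with its added hydroxy and methoxy substituents without a clear shift in the read-out. Set against the 4-chlorophenyl group, the same change gives a 1.9-fold higher number from compound 3 to compound 4 (0.29 log units; within the scatter) and also stays within the scatter, while the earlier step of a 2.3-fold lower number from compound 2 to compound 3 (0.37 log units; beyond the scatter) lies beyond it, so compound 4 falls between two compounds that stand apart and cannot be assigned clearly to either side. Nothing available on the series offers a reason for these steps.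

The compounds shown leave open whether a basic amine or a carboxylic acid on this aryl ring would carry the number beyond the scatter in either direction. They also leave open what a single hydroxy group on the phenyl ring does on the shared core, since compound 1 carries its hydroxy group on a different core and cannot be compared in one place.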